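A few compounds are considered here, and "the series" means these few. Any claim that something is new, unique, unknown or untested is made for them only; others in the source may bear on it.

Four compounds share one core and differ only in the group fixed to the outer benzene ring and in how that ring is joined to the rest. Compound 1 `FC(F)(F)c1ccc(COc2cccc(Nc3ncnc4cc5c(cc34)OCCOCCOCCOCCO5)c2)cc1` and compound 3 `O=[N+]([O-])c1ccc(COc2cccc(Nc3ncnc4cc5c(cc34)OCCOCCOCCOCCO5)c2)cc1` carry the outer ring in one arrangement; compound 2 `FC(F)(F)c1ccc(COc2ccc(Nc3ncnc4cc5c(cc34)OCCOCCOCCOCCO5)cc2)cc1` and the not yet measured compound 4 `O=[N+]([O-])c1ccc(COc2ccc(Nc3ncnc4cc5c(cc34)OCCOCCOCCOCCO5)cc2)cc1` carry it in another. The two arrangements have the same atoms joined differently, and the difference between the two cores is not broken down here.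

In a functional assay on SH-SY5Y cells (Homo sapiens) for antiproliferative activity, read by MTT assay, with a stated time of 72 h (a lower number here means a stronger inhibitor, a higher number a weaker inhibitor), compound 1 gives 8560 nM. Compound 3 differs from it by nitro in place of trifluoromethyl on an aromatic carbon and gives 8420 nM; that change gave a 1.0-fold lower number from compound 1 to compound 3 (0.01 log units; within the scatter). Compound 2 gives 2140 nM in this assay, a lower number than either compound 1 or compound 3 by an amount beyond the usual scatter.

Compound 4 stands to compound 2 as compound 3 stands to compound 1: it differs by nitro in place of trifluoromethyl on an aromatic carbon, the same change at the same place. If that change behaves as before, the step from compound 2 to compound 4 in this assay is expected to be about a 1.0-fold lower number from compound 2 to compound 4 (0.01 log units; within the scatter), because the earlier step was a 1.0-fold lower number from compound 1 to compound 3 (0.01 log units; within the scatter). Compound 4 is therefore estimated at 2100 nM in this assay, with the expected range running from 1000 nM to 4500 nM. This rests on a single earlier step, so the range is kept wide.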

Compound 4, half-maximal inhibitory concentration: > 100000 nM
Compound 4: only a limit was reported (the forecaster's own chance of this, stated with the estimate: 3%); middle value at least 47-fold (1.67 log units) away from the limit.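

On the core of compound 2, putting nitro in place of trifluoromethyl gave an at least 46-fold higher number from compound 2 to compound 4 (1.66 log units; beyond the scatter), so the near absence of change seen on the core of compound 1 did not carry over to this second core in this assay: the same change on two cores in this assay, a 1.0-fold lower number (0.01 log units; within the scatter) from compound 1 to compound 3 and an at least 46-fold higher number (1.66 log units; beyond the scatter) from compound 2 to compound 4, at least 47-fold (1.67 log units) apart, beyond the scatter of two such steps. Compound 4 gives > 100000 nM, which is a limit of the assay and not a number: the limit of > 100000 nM in this assay, at which 1 of the 4 values shown sits. Going by these compounds alone, these two pairs show that the outcome of this one change can depend on the core that carries it, so a step measured on one core was a poor guide to the other; they do not show why the two cores part ways, and with only one pair on each core they give no general rule for the series.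

From the compounds shown here alone, it remains open whether this split belongs to nitro alone or would also appear with other groups on the outer ring, such as a nitrile, a methyl group or an amine, since only trifluoromethyl and nitro are compared here on both cores. Going by these compounds, it also remains open whether the same split would appear in any test other than this assay.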